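Chloro-Dimethylamino Phenyl Ether in Place of Nitrophenyl

The source may hold more compounds than are shown below. What is called first, only, known or untested is meant among the compounds shown, and "the series" means these compounds.

Compound 1 `Cc1c(F)c(Oc2cccc(C(=N)N)c2)nc(Oc2cccc([N+](=O)[O-])c2)c1F` carries a 3-nitrophenyl ether on the shared core. In an assay on isolated protein for inhibition of serine protease 1 (Bos taurus) (a higher number here means a weaker inhibitor, a lower number a stronger inhibitor), compound 1 gives > 5000 nM, a limit rather than a number (the limit of > 5000 nM in this assay, at which 1 of the 2 values shown sits). Compound 2 `Cc1c(F)c(Oc2cccc(C(=N)N)c2)nc(Oc2cccc([S+]([O-])N(C)C)c2)c1F` replaces the nitro group with a dimethylsulfinamide, and in this assay compound 2 gives 2400 nM. Among the compounds with values here, the step of an at least 2.0-fold lower number from compound 1 to compound 2 (0.31 log units; beyond the scatter) is the only measured change on the aryl ether, and it shows that exchanging the nitro group for another neutral group brings the number below the limit.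

Compound 3 `Cc1c(F)c(Oc2cccc(C(=N)N)c2)nc(Oc2ccc(Cl)c(N(C)C)c2)c1F` differs from compound 1 by 4-chloro-3-(dimethylamino)phenyl in place of 3-nitrophenyl on an oxygen on an aromatic ring. Within the data shown here, this change has no direct measured counterpart, so the step from compound 1 to compound 2 is the only guide. Compound 3 is therefore expected to show a step of an at least 1.6-fold lower number from compound 1 to compound 3 (0.22 log units; that floor lies within the scatter) in this assay, downward from the limit and of modest size. Because compound 1 sits at the limit of > 5000 nM in this assay, at which 1 of the 2 values shown sits, the size of that step cannot be fixed from the data. Compound 3 is estimated at 3000 nM, within a range from 800 nM to 10000 nM.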

Compound 3, inhibition constant: 1000 nM
Estimate against measurement, compound 3: 3.0-fold (0.48 log units) above; the measured number falls inside the stated range.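

In this assay, the step of an at least 5.0-fold lower number from compound 1 to compound 3 (0.69 log units; beyond the scatter) is the larger of the two floors now available for this aryl ether, and it shows that the number can also fall when the nitro group is replaced by a group with no sulfur or oxygen, the 4-chloro-3-(dimethylamino)phenyl group, on an oxygen on an aromatic ring. The position therefore accepts a second, different replacement of 3-nitrophenyl, one that adds a chlorine to the ring: compound 2 gives 2400 nM, and compound 3 gives 1000 nM on the same scale. How far this step really reaches cannot be fixed, since compound 1 is recorded only as a limit and not as a number: the limit of > 5000 nM in this assay, at which 1 of the 3 values shown sits.

The compounds shown carry the chlorine and the dimethylamino group only together, so the share of each in the step stays open. Also open, as far as these compounds go, is whether a carboxylic acid or a primary amine in place of the dimethylamino group would lower the number further or raise it again.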